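Swapping a Sulfamoylphenyl Amine for Chloro

The compounds below may be only part of what the source reports. "The series", "measured", "known", "first", "only" and "open" are said of these compounds alone.

Of the compounds shown here, three have been tested in a functional assay on MCF7 cells (Homo sapiens) for cytotoxicity, with a stated time of 72 h; on this read-out higher numbers stand for weaker inhibition and lower numbers for stronger inhibition. Compound 1 (`CC1(C)Cc2c(-c3ccncc3)c(-c3ccccn3)nn2C1`) gives > 100000 nM, which is a limit of the assay and not a number. Compound 3 (`COCC1c2c(-c3ccncc3)c(-c3cccc(C)n3)nn2CC1(C)C`) gives > 100000 nM, which is also a limit and not a number. Within the data shown here, compound 2 (`Cc1cccc(-c2nn3c(c2-c2ccnc(Nc4ccc(S(N)(=O)=O)cc4)c2)C(C)C(C)(C)C3)n1`) gives 22000 nM, the only true number among the three, so it is the one firm reference point here.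

Compound 4 (`Cc1cccc(-c2nn3c(c2-c2ccnc(Cl)c2)C(C)C(C)(C)C3)n1`) has not yet been measured. It differs from compound 2 in one place, with chloro in place of (4-sulfamoylphenyl)amino on an aromatic carbon of a six-membered aromatic ring with 1 nitrogen: chloro in place of (4-sulfamoylphenyl)amino on an aromatic carbon. Among the measured compounds shown here, no two measured compounds differ in just one place, so no measured step offers a direct guide. The closest hint is the limit of > 100000 nM in this assay, at which 2 of the 3 values shown sit. The two compounds there, compound 1 and compound 3, also lack (4-sulfamoylphenyl)amino, although they differ from compound 4 elsewhere too. A moderate weakening in this assay is therefore expected, estimated as a 3.2-fold higher number from compound 2 to compound 4 (0.50 log units; beyond the scatter). A result reported only as a limit would fit this expectation as well. For compound 4 the estimated value is 70000 nM, with an expected range of 25000 nM to 100000 nM.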

Compound 4, half-maximal inhibitory concentration: > 100000 nM
Compound 4 ended at the assay's limit (the forecaster's own chance of this, stated with the estimate: 55%); middle value at least 1.4-fold (0.15 log units) away from the limit.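

Among these compounds, this is the first direct reading at this position, the aromatic carbon next to the ring nitrogen. In this assay, replacing (4-sulfamoylphenyl)amino with chloro gives an at least 4.5-fold higher number from compound 2 to compound 4 (0.65 log units; beyond the scatter), so the step is larger than the usual scatter, though only its lower bound is known. Compound 2 is still the only compound with a true number, and this single exchange takes the structure to the same ceiling as the others: the limit of > 100000 nM in this assay, at which 3 of the 4 values shown sit.

The compounds shown do not reveal which part of the (4-sulfamoylphenyl)amino group matters, as the linking nitrogen, the carbon ring and the sulfamoyl end all leave together. As far as these compounds go, a plain phenylamino group or a simple amine on the same carbon could separate these parts, while the full size of the loss stays unknown as long as the comparison rests on a limit.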